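The source may report more compounds than this note shows. Statements on the series, on what has been measured and on what is new or still open speak of the compounds shown alone.

Among the compounds with values here, compound 2, `CC(C)C[C@H](NC(=O)N1CCOCC1)C(=O)N[C@H](C#N)COCc1ccccc1Cl`, holds the lowest of the two numbers so far: in an assay for inhibition of cathepsin S (Homo sapiens) (on this read-out higher numbers stand for weaker inhibition and lower numbers for stronger inhibition), compound 2 gives 9 nM, whereas compound 1, `CC(C)C[C@H](NC(=O)N1CCOCC1)C(=O)N[C@H](C#N)CCc1ccccc1`, gives 47 nM. The measured step of a 5.2-fold lower number from compound 1 to compound 2 (0.72 log units; beyond the scatter) alters a different part of the molecule and so offers no direct guide here. Compound 3, `Cc1ccccc1COC[C@@H](C#N)NC(=O)[C@H](CC(C)C)NC(=O)N1CCOCC1`, differs from compound 2 only by methyl in place of chloro on an aromatic carbon. Within the data shown here, with no measured step bearing on this aromatic position, a change of no more than the scatter is expected in this assay. Compound 3 is therefore estimated at 12 nM, with a range from 4 nM to 40 nM, which corresponds to the expected step of a 1.3-fold higher number from compound 2 to compound 3 (0.12 log units; within the scatter).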

Compound 3, half-maximal inhibitory concentration: 19 nM
Compound 3: middle estimate off by 1.6-fold (0.20 log units), on the low side; low and high end bracket the measured number.
By their numbers in this assay, from the lowest: compound 2; then compound 3; then compound 1.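

Swapping chloro for methyl on this aromatic carbon is not neutral in this assay: it gives a 2.1-fold higher number from compound 2 to compound 3 (0.32 log units; beyond the scatter), so the two groups cannot be treated as equivalent here. The (2-methylbenzyl)oxy group still gives a 2.5-fold lower number from compound 1 to compound 3 (0.39 log units; beyond the scatter), a smaller gain than the one seen with (2-chlorobenzyl)oxy. No measurement at hand gives a reason for the gap between chloro and methyl. Other groups on this carbon, such as fluoro, methoxy or an amine, remain open. Also open, from the compounds shown here alone, is how much of the gain over compound 1 comes from the chain oxygen and how much from the ring group, as the two change together.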